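Butyl for Cyclopentyl on a Ring Nitrogen

The compounds below may be only part of what the source reports. "The series", "measured", "known", "first", "only" and "open" are said of these compounds alone.

Three compounds have been measured in a functional assay on HepG2 cells (Homo sapiens) for antiproliferative activity, read by CCK-8 assay, with a stated time of 72 h, tested at 8 uM; on this read-out lower numbers stand for a weaker effect and higher numbers for a stronger effect at the one concentration tested:

Compound 1, `Nc1ccccc1NC(=O)/C=C/c1ccc(Cn2cnc3c(Nc4cccc(OC(F)(F)F)c4)nc(Cl)nc32)cc1`: 37.6%
Compound 2, `Nc1ccccc1NC(=O)c1ccc(CNc2nc(Cl)nc3c2ncn3C2CCCC2)cc1`: 74.9%
Compound 3, `Nc1ccccc1NC(=O)c1ccc(COCNc2nc(Nc3ccccc3)c3ncn(C4CCCC4)c3n2)cc1`: 66.9%

Among these three numbers compound 3 ranks second. Its gap to compound 2 lies within the usual scatter of such measurements, so the two cannot be told apart, whereas its gap to compound 1 lies beyond the scatter. Compound 4, `CCCCn1cnc2c(Nc3ccccc3)nc(NCOCc3ccc(C(=O)Nc4ccccc4N)cc3)nc21`, differs from compound 3 in one place only: butyl in place of cyclopentyl on an aromatic nitrogen. Among the measured compounds shown here, no measured pair of compounds shows the effect of this change, so nothing beyond the scatter is expected in either direction. Compound 4 is therefore expected to give 63%, between 46% and 78%. The step of a number 3.9 percentage points lower from compound 3 to compound 4 (within the scatter) is expected to stay within the scatter.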

Compound 4, a percentage reported as inhibition, at one concentration (the size of the read-out at that concentration, not a potency): 70.7%
For compound 4 the middle estimate is 7.7 percentage points below the measured one; low and high end bracket the measured number.
By their numbers in this assay, from the lowest: compound 1; then compounds 3, 4 and 2 (each within the scatter of the next).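

Replacing cyclopentyl with butyl on the aromatic nitrogen leads, in this assay, to a number 3.8 percentage points higher from compound 3 to compound 4 (within the scatter) at the one concentration tested. At this position, then, an open four-carbon chain can stand in for a five-membered carbon ring without a change this read-out can distinguish. Nothing available explains this outcome.

On these data alone, whether a smaller group such as methyl, a longer chain such as octyl, or a chain ending in an amine or a carboxylic acid would fit this pattern remains open. So does whether the same replacement behaves alike when other groups sit on the shared core.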